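Furan-to-thiophene swap on a nucleoside-like core

The source may hold more compounds than are shown below. What is called first, only, known or untested is meant among the compounds shown, and "the series" means these compounds.

Measured compounds:
- Compound 1 `O=c1[nH]cnc2c1c(-c1ccoc1)cn2[C@@H]1O[C@H](CO)[C@@H](O)[C@H]1O`: 9030 nM
- Compound 2 `COc1ncnc2c1c(-c1ccoc1)cn2[C@@H]1O[C@H](CO)[C@@H](O)[C@H]1O`: 110 nM
- Compound 3 `O=c1[nH]cnc2c1c(-c1cccs1)cn2[C@@H]1O[C@H](CO)[C@@H](O)[C@H]1O`: a limit of the assay, > 20000 nM

In a functional assay on CCRF-CEM cells (Homo sapiens), read by MTT assay, with a stated time of 72 h (a lower number here means a stronger inhibitor, a higher number a weaker inhibitor), compound 1 gives 9030 nM. Compound 2 gives 110 nM in this assay, the lowest number among the two measured values. The difference between the two cores of compound 1 and compound 2 is not broken down here. For compound 3 this assay reports only a limit, > 20000 nM.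

Among the compounds with values here, the one change that is measured is thiophen-2-yl in place of furan-3-yl on an aromatic carbon. It gave an at least 2.2-fold higher number from compound 1 to compound 3 (0.34 log units; beyond the scatter). This is known only as a lower bound on the loss because of the limit of > 20000 nM in this assay, at which 1 of the 3 values shown sits.

Compound 4 `COc1ncnc2c1c(-c1cccs1)cn2[C@@H]1O[C@H](CO)[C@@H](O)[C@H]1O` carries the same change on the core of compound 2: thiophen-2-yl in place of furan-3-yl on an aromatic carbon. Both "place" descriptions are the same word for word, so this is the same kind of change made on a different starting core. For compound 4 the step is expected to be at least as large as the measured one, because the starting point compound 2 gives 110 nM and the earlier step is an at least 2.2-fold higher number from compound 1 to compound 3 (0.34 log units; beyond the scatter). The expected step is therefore a 5.5-fold higher number from compound 2 to compound 4 (0.74 log units; beyond the scatter), with the understanding that the measured step is only a lower bound.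

Compound 4 is estimated at 600 nM in this assay, within a range of 150 nM to 4000 nM.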

Compound 4, half-maximal inhibitory concentration: 90 nM
Compound 4: middle estimate off by 6.7-fold (0.82 log units), on the high side; measured number outside the range, below it.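

In this assay, putting thiophen-2-yl in place of furan-3-yl gives a 1.2-fold lower number from compound 2 to compound 4 (0.09 log units; within the scatter), so on this core the swap makes no clear difference. The same swap on the other core behaves differently, which means that a step measured on one core cannot simply be carried over to the other in this series: the same change on two cores in this assay, an at least 2.2-fold higher number (0.34 log units; beyond the scatter) from compound 1 to compound 3 and a 1.2-fold lower number (0.09 log units; within the scatter) from compound 2 to compound 4, at least 2.7-fold (0.43 log units) apart, beyond the scatter of two such steps. This does not show how large the loss on the core of compound 1 really is, nor why the two cores respond differently, and the size of that gap stays uncertain since compound 3 is reported only as a limit: the limit of > 20000 nM in this assay, at which 1 of the 4 values shown sits.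

As far as these compounds go, only furan-3-yl and thiophen-2-yl appear on this aromatic carbon, so it remains open whether other groups, such as a phenyl ring or a pyridine ring, would also depend on the core. With just two cores shown, it is also open how a third core, for instance one carrying an amine at the place where these two cores differ, would respond to the same swap.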